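The compounds below may be only part of what the source reports. "The series", "measured", "known", "first", "only" and "open" are said of these compounds alone.

Measured in an assay for inhibition of histone-lysine N-methyltransferase, H3 lysine-79 specific (Homo sapiens), read by scintillation counting, with stated times of 15 min and 60 min, tested at 50 uM, in the presence of a further agent that is not named here; a lower number here means a weaker effect, a higher number a stronger effect of the compound at the concentration tested:
compound 1 `C(=C/c1nn2c(C3CCCCC3)nnc2s1)\c1ccco1` gives 68%
compound 2 `COc1ccccc1-c1nnc2sc(/C=C/c3ccco3)nn12` gives 75%
compound 3 `Cc1occc1-c1nnc2sc(CCCc3ccccc3)nn12` gives 17%

Compound 1 stands second highest of the three numbers in this assay. Compound 2 is nearest and lies within the scatter, so the two cannot be ranked against each other. Compound 3 is furthest, well below compound 1 and beyond the scatter.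

Compound 4 `C(=C/c1nn2c(-c3ccncc3)nnc2s1)\c1ccco1` is not yet measured. Against compound 1 the change is: pyridin-4-yl in place of cyclohexyl on an aromatic carbon. Going by the values given here, no pair of measured compounds differs in this place alone, so the size of the step is open. Given that compound 1 at 68% and compound 2 at 75% fall in the same range, no step beyond the scatter is expected in this assay, in either direction. Compound 4 is expected to give 68%, in the range 45% to 85%. The expected step of no change at the digits printed from compound 1 to compound 4 (within the scatter) stays within the scatter.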

Compound 4, a percentage reported as inhibition, at one concentration (the size of the read-out at that concentration, not a potency): 67%
Compound 4: middle estimate off by 1 percentage points, on the high side; the range from low to high includes it.
By their numbers in this assay, from the lowest: compound 3; then compounds 4, 1 and 2 (each within the scatter of the next).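

Pyridin-4-yl in place of cyclohexyl on an aromatic carbon gives a number 1 percentage points lower from compound 1 to compound 4 (within the scatter) in this assay. With the rest of compound 1 held fixed, this place therefore takes both a ring of carbon only and an aromatic ring carrying a hydrogen-bond acceptor without a step beyond the scatter. Nothing at hand explains this result. Still open, from the compounds shown here alone, is whether a much smaller group such as methyl, or an amine or a carboxylic acid, would leave the read-out at this place equally unmoved.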